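Methyl scan on the anilino ring of compound 1

The compounds below may be only part of what the source reports. "The series", "measured", "known", "first", "only" and "open" are said of these compounds alone.

Measured so far:
compound 1 `CCn1c(Nc2ccccc2)nc2ccsc2c1=O` — 290 nM
compound 2 `CCn1c(Nc2ccccc2C)nc2ccsc2c1=O` — 88 nM

Both compounds have been run in an assay on isolated protein for inhibition of high affinity 3',5'-cyclic-AMP phosphodiesterase 7A (Homo sapiens); a lower number here means a stronger inhibitor, a higher number a weaker inhibitor. In this assay compound 1 gives 290 nM, the highest of the two numbers recorded; its nearest neighbour is compound 2 with 88 nM. Going by the values given here, the one step available, a 3.3-fold lower number from compound 1 to compound 2 (0.52 log units; beyond the scatter), is methyl in place of hydrogen on an aromatic carbon.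

The step to be followed here is from compound 1 to compound 3 `CCn1c(Nc2cccc(C)c2)nc2ccsc2c1=O`. The change is methyl in place of hydrogen on an aromatic carbon. It is the same kind of change as the step from compound 1 to compound 2, a methyl entering for a hydrogen on the same anilino ring, but at the site described as meta to a large group rather than the site used in compound 2. Among the compounds with values here, the only guide is therefore a 3.3-fold lower number from compound 1 to compound 2 (0.52 log units; beyond the scatter), which was beyond the scatter but modest. An improvement of similar or somewhat smaller size is expected in this assay, but nothing in the data fixes whether the effect carries over to this site. The step is estimated as a 1.9-fold lower number from compound 1 to compound 3 (0.29 log units; within the scatter). Compound 3 is expected to give about 150 nM, within 60 nM to 400 nM.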

Compound 3, half-maximal inhibitory concentration: > 1000 nM
Compound 3: a limit, no number; the forecaster's own chance of this, stated with the estimate: 2%; middle value at least 6.6-fold (0.82 log units) away from the limit.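

In this assay compound 3 gives > 1000 nM, a limit of the assay and not a number. On the anilino ring the same change, methyl in place of hydrogen on an aromatic carbon, now points in two directions: at the site used in compound 2 it gives a 3.3-fold lower number from compound 1 to compound 2 (0.52 log units; beyond the scatter), while meta to a large group it gives an at least 3.4-fold higher number from compound 1 to compound 3 (0.53 log units; beyond the scatter). The outcome of this change therefore depends on the site of the methyl and not on the methyl alone, and the step to compound 3 is bounded on one side only: the limit of > 1000 nM in this assay, at which 1 of the 3 values shown sits.

As far as these compounds go, two sites on one ring do not establish a pattern, so how a methyl reads on the other carbons of the anilino ring remains open. Also open, from the compounds shown here alone, is whether a different group meta to a large group, such as a methoxy group, a chlorine atom, a hydroxyl group or a longer chain such as ethyl, would read in this assay as the methyl of compound 3 does or would bring the number back towards that of compound 1.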